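Lengthening a Sulfonyl Chain in Three Inactive Analogues

The source may hold more compounds than are shown below. What is called first, only, known or untested is meant among the compounds shown, and "the series" means these compounds.

Three compounds built on one shared core were tested in a functional assay on MDA-MB-231 cells (Homo sapiens) for antiproliferative activity, read by MTT assay, with a stated time of 24 h; a lower number here means a stronger inhibitor, a higher number a weaker inhibitor. Compound 1, `CSc1nnc(COc2cc(C)c3c(C)cc(=O)oc3c2)o1`, carries a methylsulfanyl group on its five-membered aromatic ring. In this assay compound 1 gives > 100000 nM, which is a limit of the assay rather than a number. Compound 2, `CCSc1nnc(COc2cc(C)c3c(C)cc(=O)oc3c2)o1`, differs from compound 1 by methyl in place of hydrogen on a saturated chain carbon bound to a sulfur. In this assay compound 2 gives > 100000 nM, again a limit. Compound 3, `CCS(=O)(=O)c1nnc(COc2cc(C)c3c(C)cc(=O)oc3c2)o1`, differs from compound 1 by ethylsulfonyl in place of methylsulfanyl on an aromatic carbon. In this assay compound 3 gives > 100000 nM, once more a limit. The steps a step that the two limits leave unreadable from compound 1 to compound 2, a step that the two limits leave unreadable from compound 1 to compound 3 and a step that the two limits leave unreadable from compound 2 to compound 3 therefore cannot be sized, since every value rests at the limit of > 100000 nM in this assay, at which 3 of the 3 values shown sit.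

Compound 4, `CCCS(=O)(=O)c1nnc(COc2cc(C)c3c(C)cc(=O)oc3c2)o1`, is not yet measured in this assay. It differs from compound 3 by methyl in place of hydrogen on a saturated chain carbon, two bonds along the chain from a sulfonyl sulfur. Within the data shown here, that is the same kind of change as the one from compound 1 to compound 2, though not the same: there the methyl entered on a saturated chain carbon bound to a sulfur, here it enters on a saturated chain carbon, two bonds along the chain from a sulfonyl sulfur. The earlier step that the two limits leave unreadable from compound 1 to compound 2 gave no readable movement, and compound 3 itself sits at the limit, so compound 4 is expected to stay weak. The expected step that the limit leaves unreadable from compound 3 to compound 4 is estimated to be small. Compound 4 is estimated at 150000 nM, expected to fall between 50000 nM and 500000 nM, most likely reported as a limit again.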

Compound 4, half-maximal inhibitory concentration: 7070 nM
For compound 4 the middle estimate is 21-fold (1.33 log units) above the measured one; the measured number lies below the stated range.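

In this assay, extending the ethylsulfonyl chain to a propylsulfonyl chain by one methyl gives an at least 14-fold lower number from compound 3 to compound 4 (1.15 log units; beyond the scatter), and replacing the sulfanyl groups on the same aromatic carbon with propylsulfonyl gives an at least 14-fold lower number from compound 2 to compound 4 (1.15 log units; beyond the scatter) and an at least 14-fold lower number from compound 1 to compound 4 (1.15 log units; beyond the scatter). On this sulfonyl compound, then, one added methyl is enough to move a compound from the limit to a measurable value, but this rests on a single pair and does not show that the same methyl would have a similar effect on another core. The closest comparison, methyl added to the chain carbon bound to sulfur, and the other steps among compound 1, compound 2 and compound 3 cannot be read, because all of those values rest at one limit: the limit of > 100000 nM in this assay, at which 3 of the 4 values shown sit.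

The compounds shown leave open whether propylsulfanyl would also bring a measurable value, so the part played by the chain cannot be separated from that of the sulfonyl in the two larger replacements. They also leave open whether a longer chain such as butylsulfonyl would lower the number further, or whether an amine at the end of the chain would keep the activity.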